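A Chlorobenzyl Group in Place of an Amide

The source may report more compounds than this note shows. Statements on the series, on what has been measured and on what is new or still open speak of the compounds shown alone.

Three measured compounds share one core and differ only at the far end of the molecule. In a functional assay on SH-SY5Y cells (Homo sapiens) for inhibition, read by sulforhodamine B assay (on this read-out lower numbers stand for stronger inhibition and higher numbers for weaker inhibition), compound 1 `COC(=O)CC/C(C)=C/Cc1c(OC)c(C)c2c(c1OCC#CCN1CCC(C(=O)OC)CC1)C(=O)OC2` gives 41200 nM, and compound 3 `COC(=O)CC/C(C)=C/Cc1c(OC)c(C)c2c(c1OCC#CCN1CCC(Cc3ccccc3)CC1)C(=O)OC2` gives 24500 nM. The step of a 1.7-fold lower number from compound 1 to compound 3 (0.23 log units; within the scatter) is therefore small. Compound 2 `COC(=O)CC/C(C)=C/Cc1c(OC)c(C)c2c(c1OCC#CCN1CCN(C(=O)C3COc4ccccc4O3)CC1)C(=O)OC2` stands apart: in this assay it reaches only a limit, > 50000 nM, so no number is known for it (the limit of > 50000 nM in this assay, at which 1 of the 3 values shown sits). Compound 4 `COC(=O)CC/C(C)=C/Cc1c(OC)c(C)c2c(c1OCC#CCN1CCN(Cc3ccc(Cl)cc3)CC1)C(=O)OC2` is the unmeasured partner of compound 2, with 4-chlorobenzyl in place of (2,3-dihydro-1,4-benzodioxin-2-yl)carbonyl on an amine nitrogen in a ring. Among the measured compounds shown here, no measured step covers this exact change. For the measured compounds named here, the only measured step, from compound 1 to compound 3, puts benzyl in place of methoxycarbonyl on a saturated ring carbon and stays within the scatter, which gives little reason to expect a large jump here. The starting point itself is uncertain, since compound 2 sits at the limit. The expected step of an at least 1.4-fold lower number from compound 2 to compound 4 (0.15 log units; that floor lies within the scatter) is small, towards somewhat stronger inhibition. Compound 4 is thus estimated to give about 35000 nM, within a range from 12000 nM to 100000 nM.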

Compound 4, half-maximal inhibitory concentration: 31200 nM
Compound 4: the middle estimate sits 1.1-fold (0.05 log units) above what was measured; the range from low to high includes it.
By their numbers in this assay, from the lowest: compounds 3, 4 and 1 (each within the scatter of the next). At a limit, above all of these: compound 2.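

With 4-chlorobenzyl on the amine nitrogen in the ring, compound 4 gives 31200 nM in this assay, so this position, with no carbonyl attached, yields a readable number. The step is an at least 1.6-fold lower number from compound 2 to compound 4 (0.20 log units; that floor lies within the scatter); only this floor is known, and it does not show that the swap strengthens inhibition. On these data alone, the true size of the step remains unknown because the value for compound 2 is only a limit: the limit of > 50000 nM in this assay, at which 1 of the 4 values shown sits.

As far as these compounds go, it remains open what the chlorine itself contributes, and how a plain benzyl on this nitrogen would compare with the 4-chlorobenzyl of compound 4. From the compounds shown here alone, it is also open how this position would respond to a longer chain ending in an amine or a carboxylic acid.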